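A few compounds are considered here, and "the series" means these few. Any claim that something is new, unique, unknown or untested is made for them only; others in the source may bear on it.

In an ADME assay on microsomes from liver (Rattus norvegicus) for metabolic stability, read by LC-MS, using NADPH, at 37 degrees C (on this read-out higher numbers stand for a longer-lived compound and lower numbers for a shorter-lived compound), compound 1 `Cc1ccc(C)c(-c2nc(CN3CCC(C(=O)NCCCN4C[C@H](C)C[C@H](C)C4)CC3)c(C)o2)c1` gives 0.5 h, the higher of the two exact numbers. Compound 2 `CC[C@@H]1C[C@H](CC)CN(CCCNC(=O)C2CCN(Cc3nc(-c4ccccc4C)oc3C)CC2)C1` gives 0.0917 h. The gap between these two numbers lies beyond the scatter. Compound 3 `Cc1ccccc1-c1nc(CN2CCC(C(=O)NCCCN3CCC(C)(C)CC3)CC2)c(C)o1` reads > 0.5 h, which is a limit of the assay. Compound 4 `Cc1oc(-c2c(Br)cccc2Br)nc1CN1CCC(C(=O)NCCCN2C[C@H](C)C[C@H](C)C2)CC1` carries 2,6-dibromophenyl in place of 2,5-dimethylphenyl on an aromatic carbon. Among the compounds with values here, the only measured step, an at least 5.4-fold higher number from compound 2 to compound 3 (0.73 log units; beyond the scatter), lies beyond the scatter, but it exchanges 3,5-diethylpiperidin-1-yl for 4,4-dimethylpiperidin-1-yl and leaves the phenyl group untouched. Within the data shown here, no measured step therefore bears directly on this change, and no shift beyond the scatter is expected in this assay. The expected change is a 1.3-fold lower number from compound 1 to compound 4 (0.10 log units; within the scatter). For compound 4 the estimated half-life is 0.4 h, with an expected range of 0.15 h to 0.9 h.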

Compound 4, half-life: 0.035 h
The estimate for compound 4 lay 11-fold (1.06 log units) above the measured number; the measured number lies below the stated range.
By their numbers in this assay, from the lowest: compound 4; then compound 2; then compound 1.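

In this assay, the step of a 14-fold lower number from compound 1 to compound 4 (1.15 log units; beyond the scatter) shows that the group on this aromatic carbon of the five-membered ring strongly affects half-life, and that exchanging 2,5-dimethylphenyl for 2,6-dibromophenyl does not leave it unchanged. The earlier step of an at least 5.4-fold higher number from compound 2 to compound 3 (0.73 log units; beyond the scatter) concerned only the piperidine group on the chain, so it said nothing about this place. No measurement shown here explains the drop. From the compounds shown here alone, whether the bromine atoms or their placement on the phenyl ring drive this drop remains open, and so does the effect of 2,6-dimethylphenyl or 2,6-dichlorophenyl at this place.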